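Chain substituent variation at the shared core

The source may hold more compounds than are shown below. What is called first, only, known or untested is meant among the compounds shown, and "the series" means these compounds.

Compound 1 `CCCCNc1nc(N)nc(C)c1C` gives 3280 nM in an assay on HEK293 cells for agonist activity at Toll-like receptor 8 (Homo sapiens), read by spectrophotometry; a lower number here means that less compound is needed, a higher number that more compound is needed for the effect.
Compound 2 `CCCCNc1nc(N)nc(C)c1CCCn1cccn1` gives 1050 nM in this assay.
Compound 3 `CCCCNc1nc(N)nc(C)c1CCCN1CCCCC1` gives 133 nM in this assay.

Compound 3 has the lowest number of the three: a 7.9-fold lower number from compound 2 to compound 3 (0.90 log units; beyond the scatter), and compound 1 lies further off still. Compound 4 `CCCCNc1nc(N)nc(C)c1CCc1ccccc1` differs from compound 3 as follows: phenyl in place of (piperidin-1-yl)methyl on a saturated chain carbon, two bonds along the chain from an aromatic carbon. For the measured compounds named here, two measured steps bear on this. First, a 3.1-fold lower number from compound 1 to compound 2 (0.49 log units; beyond the scatter); second, a 7.9-fold lower number from compound 2 to compound 3 (0.90 log units; beyond the scatter), which shows how much of the standing of compound 3 rests on the piperidin-1-yl. Compound 4 keeps a chain on the core but carries an aromatic ring of carbon only in place of that group, which places it nearer compound 2 than compound 3. A step back toward the number of compound 2 is therefore expected: a 9.0-fold higher number from compound 3 to compound 4 (0.96 log units; beyond the scatter). Compound 4 is estimated at 1200 nM, within 300 nM to 5000 nM.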

Compound 4, half-maximal effective concentration: 1190 nM
Compound 4: the middle estimate sits 1.0-fold (0.00 log units) above what was measured, within the range that was stated.
By their numbers in this assay, from the lowest: compound 3; then compounds 2 and 4 (each within the scatter of the next); then compound 1.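

Replacing (piperidin-1-yl)methyl with phenyl gives an 8.9-fold higher number from compound 3 to compound 4 (0.95 log units; beyond the scatter), so the standing of compound 3 does not survive this change, although ring and chain length change together here. Phenyl and (1H-pyrazol-1-yl)methyl sit level at this place, with a 1.1-fold higher number from compound 2 to compound 4 (0.05 log units; within the scatter), while benzyl in place of hydrogen still gives a 2.8-fold lower number from compound 1 to compound 4 (0.44 log units; beyond the scatter) and so retains a modest gain. No measured evidence bears on these differences.

Still open, going by these compounds, is whether the piperidine nitrogen or the saturated ring carries the gain, which cyclohexyl or an open-chain dimethylamino group on the same chain would separate. A longer chain ending in phenyl would isolate the contribution of chain length.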